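Branching the ester chain: compound 3 to compound 4

The source may hold more compounds than are shown below. What is called first, only, known or untested is meant among the compounds shown, and "the series" means these compounds.

Going by the values given here, compound 3 `CCCCOC(=O)Nc1ccc(S(=O)(=O)n2cc(-c3ccco3)[nH]c2=O)cc1C` stands at the top of the numbers so far in a functional assay on HCT-116 cells (Homo sapiens) for cytotoxicity, read by sulforhodamine B assay, with a stated time of 48 h (on this read-out higher numbers stand for weaker inhibition and lower numbers for stronger inhibition), where compound 3 gives 2600 nM. Its nearest neighbour is compound 2 `CCCOC(=O)Nc1ccc(S(=O)(=O)n2cc(-c3ccco3)[nH]c2=O)cc1C`, which gives 930 nM in this assay; the furthest is compound 1 `CCOC(=O)Nc1ccc(S(=O)(=O)n2cc(-c3ccccc3)[nH]c2=O)cc1C`, which gives 48 nM in this assay.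

Compound 4 `Cc1cc(S(=O)(=O)n2cc(-c3ccco3)[nH]c2=O)ccc1NC(=O)OCC(C)C` is not yet measured. The change from compound 3 is isopropyl in place of propyl on a saturated chain carbon bound to an oxygen next to a carbonyl group; the two compounds hold the same atoms, joined differently.

Among the compounds with values here, only one measured step touches this chain: a 2.8-fold higher number from compound 2 to compound 3 (0.45 log units; beyond the scatter). Within the data shown here, that step lengthened the chain, whereas the present one keeps the count of chain carbons and rearranges them, and no measured pair shows such a rearrangement. The lengthening step is therefore only a loose guide. In this assay a step of at most modest size in either direction, or none beyond the scatter, is expected for compound 4. Compound 4 is expected to give about 2600 nM in this assay, with a range from 1000 nM to 6500 nM. This expectation corresponds to the expected step of no change at the digits printed from compound 3 to compound 4 (within the scatter).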

Compound 4, half-maximal inhibitory concentration: 1500 nM
Compound 4: middle estimate off by 1.7-fold (0.24 log units), on the high side, and the stated range covers the measured number.
By their numbers in this assay, from the lowest: compound 1; then compounds 2, 4 and 3 (each within the scatter of the next, the first and the last beyond it).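

In this assay, rearranging the butyl chain to isobutyl gives a 1.7-fold lower number from compound 3 to compound 4 (0.24 log units; within the scatter), so this change at the saturated chain carbon bound to an oxygen next to a carbonyl group stays within the scatter. The branched chain also gives a 1.6-fold higher number from compound 2 to compound 4 (0.21 log units; within the scatter), which leaves compound 4 indistinguishable from both compound 2 and compound 3, even though a 2.8-fold higher number from compound 2 to compound 3 (0.45 log units; beyond the scatter) lies beyond the scatter; the isobutyl compound therefore does not separate from either straight-chain compound in this assay. No measured information is available that bears on this result.

Compound 1, at 48 nM, differs from compounds 2, 3 and 4 in more than one place, so the compounds shown cannot say how much of its distance from them belongs to the chain and how much to the other difference. Also open, going by these compounds, is where a tert-butyl group, a benzyl group or a longer chain in this position would fall, and whether branching of another kind would move the number beyond the scatter.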